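This account rests on a few compounds, and the source may have more. Where it says the series, first, only, none or still open, it means among the compounds named here.

Three measured compounds share a core and were each tested in a functional assay on MOLT-4 cells (Homo sapiens) for cytotoxicity, read by MTT assay, with a stated time of 72 h; on this read-out lower numbers stand for stronger inhibition and higher numbers for weaker inhibition. Compound 1 `COc1cc(/C=C/C(=O)c2cc3cc(O)ccc3oc2=O)cc(OC)c1OC` gives 3900 nM in this assay. Compound 2 `COc1cccc(/C=C/C(=O)c2cc3cc(O)ccc3oc2=O)c1OC` gives 6700 nM; the difference between the two cores is not broken down here, and the two numbers lie within the usual scatter of each other, so no order can be read between them. Compound 3 `COc1cccc(/C=C/C(=O)c2cc3cc(OCc4ccccc4)ccc3oc2=O)c1OC` gives 23600 nM. Compound 3 differs from compound 2 by a single change, (benzyl in place of hydrogen on an oxygen on an aromatic ring), and this change made a step of a 3.5-fold higher number from compound 2 to compound 3 (0.55 log units; beyond the scatter).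

Compound 4 `COc1cc(/C=C/C(=O)c2cc3cc(OCc4ccccc4)ccc3oc2=O)cc(OC)c1OC` has not yet been measured. It differs from compound 1 by the same change, (benzyl in place of hydrogen on an oxygen on an aromatic ring), made at a place described in exactly the same words as for the pair before, so it is treated as the same change. Within the data shown here, with only one earlier example of this change, the expectation rests on that one case: the expected step is a 3.3-fold higher number from compound 1 to compound 4 (0.52 log units; beyond the scatter) because the same change earlier gave a 3.5-fold higher number from compound 2 to compound 3 (0.55 log units; beyond the scatter). Whether the change behaves the same on the core of compound 1 as on the core of compound 2 is not known from the data, which is why the range is kept wide. On that basis compound 4 is expected to give about 13000 nM in this assay, most likely between 6000 nM and 30000 nM.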

Compound 4, half-maximal inhibitory concentration: 10300 nM
The estimate for compound 4 lay 1.3-fold (0.10 log units) above the measured number; the measured number falls inside the stated range.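

Replacing the hydrogen of the hydroxy group with benzyl, which turns hydroxy into benzyloxy, gave a 2.6-fold higher number from compound 1 to compound 4 (0.42 log units; beyond the scatter) in this assay, so the weakening seen on the core of compound 2 also appears on the core of compound 1. The two steps point the same way and cannot be told apart in size, so the change carried over between these two cores: the same change on two cores in this assay, a 3.5-fold higher number (0.55 log units; beyond the scatter) from compound 2 to compound 3 and a 2.6-fold higher number (0.42 log units; beyond the scatter) from compound 1 to compound 4, 1.3-fold (0.13 log units) apart, within the scatter of two such steps. Among these compounds, this rests on only two pairs in one cell assay, so it does not show that the change would behave the same way on any other core or in any other test.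

The compounds shown leave open how a methyl group, a longer chain, or a chain ending in an amine or a carboxylic acid on that same oxygen would read in this assay. From the compounds shown here alone, both pairs also remove the hydrogen and add the ring in one move, so it remains open whether the weakening follows the loss of that hydrogen or the arrival of the benzyl group.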